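The source may hold more compounds than are shown below. What is called first, only, known or untested is meant among the compounds shown, and "the series" means these compounds.

Measured compounds:
Compound 1 `CCOC(=O)c1c(-c2cccc(Br)c2)[nH]c2cc(OC)ccc2c1=O`: > 21500 nM, a limit
Compound 2 `CCOC(=O)c1c(-c2cccc(NC(C)=O)c2)[nH]c2cc(OC)ccc2c1=O`: > 21500 nM, a limit

Both compounds were tested in an ADME assay on Raji cells (Homo sapiens) for cytotoxicity, read by luminescence, with a stated time of 72 h; a lower number here means that less compound is needed, a higher number that more compound is needed for the effect. Compound 2 stands at > 21500 nM, which is a limit and not a number. Compound 1 likewise gives only a limit, so the two share (the limit of > 21500 nM in this assay, at which 2 of the 2 values shown sit). Going by the values given here, the one measured step, a step that the two limits leave unreadable from compound 1 to compound 2, therefore has no readable size.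

Compound 3 `CCOC(=O)c1c(-c2cccc(O)c2)[nH]c2cc(OC)ccc2c1=O` has hydroxy in place of acetamido on an aromatic carbon, meta to a large group: hydroxy in place of acetamido on an aromatic carbon. Among the compounds with values here, only the step to compound 2 bears on this change, and it gives neither a size nor a direction. Within the data shown here, no step of definite size is therefore expected in this assay, and a further limit is the likeliest reading. The estimated value for compound 3 is 25000 nM, with an expected range from 9000 nM to 60000 nM. The expected change is a step that the limit leaves unreadable from compound 2 to compound 3.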

Compound 3, half-maximal effective concentration: > 21500 nM
Compound 3: no number, only a limit (the forecaster's own chance of this, stated with the estimate: 80%); the middle value lies beyond the limit too.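

In this assay compound 3 gives > 21500 nM, a limit and not a number. Going by these compounds alone, no step among compound 1, compound 2 and compound 3 can therefore be read: the limit of > 21500 nM in this assay, at which 3 of the 3 values shown sit. The compounds shown leave open whether bromo, acetamido and hydroxy differ at all in this assay.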